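Replacing the 3-nitrophenyl group of compound 1

A few compounds are considered here, and "the series" means these few. Any claim that something is new, unique, unknown or untested is made for them only; others in the source may bear on it.

compound 1 `O=C(N/N=C/c1cccc([N+](=O)[O-])c1)Nc1ccc(Oc2ccnc3[nH]ccc23)c(F)c1` gives 5180 nM
compound 2 `CC(C)(C)c1cc(/C=N/NC(=O)Nc2ccc(Oc3ccnc4[nH]ccc34)c(F)c2)cc(C(C)(C)C)c1O` gives 7220 nM

In a functional assay on HepG2 cells (Homo sapiens) for antiproliferative activity, read by MTT assay, with a stated time of 72 h (a higher number here means a weaker inhibitor, a lower number a stronger inhibitor), compound 1 gives 5180 nM and compound 2 gives 7220 nM. These two values lie within the scatter of each other, so compound 1 cannot be ranked against compound 2. Among the compounds with values here, no single-place step connects the two measured compounds.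

The next compound is compound 3 `O=C(N/N=C/c1ccc(O)c(Br)c1)Nc1ccc(Oc2ccnc3[nH]ccc23)c(F)c1`, which keeps the shared core of compound 1 and has 3-bromo-4-hydroxyphenyl in place of 3-nitrophenyl on a carbon with a double bond to nitrogen. Within the data shown here, the data hold no direct precedent for this exchange. Among the measured compounds shown here, the only guide is that compound 2 (7220 nM), with a different group on that carbon, stays within the scatter of compound 1 (5180 nM). On that limited evidence, no step beyond the scatter is expected in this assay and no direction can be argued. The estimated step is a 1.1-fold lower number from compound 1 to compound 3 (0.03 log units; within the scatter) and is expected to stay within the scatter. Compound 3 is expected at 4800 nM (estimated range 1800 nM to 13000 nM).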

Compound 3, half-maximal inhibitory concentration: 1360 nM
Compound 3: middle estimate off by 3.5-fold (0.55 log units), on the high side; measured number below the stated range.
By their numbers in this assay, from the lowest: compound 3; then compounds 1 and 2 (each within the scatter of the next).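

In this assay the group on the carbon with a double bond to nitrogen is now shown to affect the read-out: 3-bromo-4-hydroxyphenyl in place of 3-nitrophenyl gives a 3.8-fold lower number from compound 1 to compound 3 (0.58 log units; beyond the scatter) and so provides the first single-place step of the series, one that lies beyond the scatter. The six-membered aromatic ring of carbon only is kept and the shared core is unchanged, so the step goes with the change in what the ring carries, which here also moves the count from 0 hydrogen-bond donors and 2 hydrogen-bond acceptors to 1 hydrogen-bond donor and 1 hydrogen-bond acceptor. No measurement in hand explains the step.

This single exchange removes the nitro group and brings in the bromine and the hydroxyl together, so the compounds shown cannot divide the step between the two incoming substituents, and a ring carrying only one of them would be needed to do so. Also open, as far as these compounds go, is how an unsubstituted phenyl, or a phenyl bearing an amine or a carboxylic acid, would read on this carbon in this assay.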